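Trifluoromethyl Instead of Acetyl on the Aryl Oxygen

This account rests on a few compounds, and the source may have more. Where it says the series, first, only, none or still open, it means among the compounds named here.

Compound 1 `C=CC[C@H]1C[C@]2([C@@H](C)Cc3ccc(OC)cc3)OCOC2=CC1=O`: 90 nM
Compound 2 `C=CC[C@H]1C[C@]2([C@@H](C)Cc3ccc(OC(C)=O)cc3)OCOC2=CC1=O`: > 20000 nM

Compound 1 is the measured anchor, giving 90 nM in a functional assay on NCI-H460 cells (Homo sapiens) for antiproliferative activity, with a stated time of 72 h; on this read-out higher numbers stand for weaker inhibition and lower numbers for stronger inhibition. Compound 2 reached only a limit in this assay, > 20000 nM, so it sits at the limit of > 20000 nM in this assay, at which 1 of the 2 values shown sits, and no number is known for it. Among the compounds with values here, the one measured step, an at least 220-fold higher number from compound 1 to compound 2 (2.34 log units; beyond the scatter), therefore gives the size of the change in the other direction only as a lower bound.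

Compound 3 `C=CC[C@H]1C[C@]2([C@@H](C)Cc3ccc(OC(F)(F)F)cc3)OCOC2=CC1=O` carries trifluoromethyl in place of acetyl on an oxygen on an aromatic ring. Within the data shown here, this change has no measured counterpart: the only step known concerns methyl against acetyl, and the new group is neither. Starting from a limit, a step of any size toward stronger inhibition would be consistent with what is shown, while a value near the limit is equally possible. For compound 3 a step of an at least 10-fold lower number from compound 2 to compound 3 (1.00 log units; beyond the scatter) is expected, with wide uncertainty. Compound 3 is accordingly estimated at 2000 nM, between 150 nM and 20000 nM, in this assay.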

Compound 3, half-maximal inhibitory concentration: 3800 nM
For compound 3 the middle estimate is 1.9-fold (0.28 log units) below the measured one; the measured number falls inside the stated range.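

On an oxygen on an aromatic ring, the group decides more than simply whether a measurable number appears in this assay: trifluoromethyl gives a real value where acetyl gave none, with an at least 5.2-fold lower number from compound 2 to compound 3 (0.72 log units; beyond the scatter), yet it does not restore the level of the methyl compound, with a 42-fold higher number from compound 1 to compound 3 (1.63 log units; beyond the scatter). Compound 2 stays a limit, so the first of these steps is only a lower bound: (the limit of > 20000 nM in this assay, at which 1 of the 3 values shown sits). Of the three groups shown at this place, methyl gives the strongest inhibition, and the three compounds spread over a wide range from a single change.

As far as these compounds go, how far the gap between acetyl and trifluoromethyl really extends stays unknown without a number for compound 2. From the compounds shown here alone, whether a free hydroxyl, an amine or a longer chain such as ethyl on this oxygen would come closer to compound 1 also remains open.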